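The source may hold more compounds than are shown below. What is called first, only, known or untested is meant among the compounds shown, and "the series" means these compounds.

In a functional assay on K562 cells (Homo sapiens) for antiproliferative activity, read by MTT assay, with a stated time of 48 h (a lower number here means a stronger inhibitor, a higher number a weaker inhibitor), compound 1 (`Cn1c(N)c(-c2nc3ccccc3[nH]2)c2nc(C#N)c(C#N)nc21`) gives > 50000 nM, which is a limit of the assay and not a number. For the measured compounds named here, compound 2 (`CCN(CC)CCCn1c(N)c(-c2nc3ccccc3[nH]2)c2nc(C#N)c(C#N)nc21`) gives 1800 nM, the only actual number so far. Compound 3 (`CN1CCN(CCCn2c(N)c(-c3nc4ccccc4[nH]3)c3nc(C#N)c(C#N)nc32)CC1`) has 4-methylpiperazin-1-yl in place of diethylamino on a saturated chain carbon, three bonds along the chain from an aromatic nitrogen. Going by the values given here, the only measured step that bears on this is an at least 27-fold lower number from compound 1 to compound 2 (1.44 log units; beyond the scatter), a large one that brings in the whole diethylamino-ended chain. Compound 3 alters only the end of that chain, so this step sets no size for the exchange, and no step beyond the scatter is expected in this assay. The expected change is a 1.4-fold higher number from compound 2 to compound 3 (0.14 log units; within the scatter). For compound 3 the estimated value is 2500 nM, with an expected range of 800 nM to 8000 nM.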

Compound 3, half-maximal inhibitory concentration: 1260 nM
The estimate for compound 3 lay 2.0-fold (0.30 log units) above the measured number, within the range that was stated.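

In this assay, 4-methylpiperazin-1-yl in place of diethylamino, on a saturated chain carbon, three bonds along the chain from an aromatic nitrogen, gives a 1.4-fold lower number from compound 2 to compound 3 (0.15 log units; within the scatter) and so leaves no readable difference between the two chain ends. The large drop seen with the diethylamino-ended chain recurs with a six-membered ring at the chain end, as an at least 39-fold lower number from compound 1 to compound 3 (1.59 log units; beyond the scatter) shows, so across these compounds it does not depend on diethylamino alone. Compound 1 has a limit of the assay and not a number, so the step from it gives only a minimum size: the limit of > 50000 nM in this assay, at which 1 of the 3 values shown sits.

The compounds shown leave open whether a chain ending in a group without nitrogen, such as a hydroxyl, would reach the same level. They also leave open how a shorter or longer chain than 3-(4-methylpiperazin-1-yl)propyl would compare, for instance an ethyl or butyl linker to the same ring.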